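The compounds below may be only part of what the source reports. "The series", "measured", "known", "first", "only" and "open" are said of these compounds alone.

In a functional assay on FM3A cells (Mus musculus) for antiproliferative activity, read by cell counting, with a stated time of 2 days (on this read-out higher numbers stand for weaker inhibition and lower numbers for stronger inhibition), the measured compounds are these
- compound 1 `COc1ccc(Nc2nc(N)c(C(=O)c3ccccc3)s2)cc1` gives 730 nM
- compound 2 `COc1ccc(C(=O)c2sc(Nc3ccc(Cl)cc3)nc2N)cc1` gives > 10000 nM as a limit
- compound 3 `Nc1nc(Nc2ccc(Cl)cc2)sc1C(=O)c1ccccc1` gives > 10000 nM as a limit

Compound 3 stands at > 10000 nM as a limit and not as a number. Its position is the limit of > 10000 nM in this assay, at which 2 of the 3 values shown sit, and no more can be read from it.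

The change to compound 4 `Nc1nc(Nc2ccc(F)cc2)sc1C(=O)c1ccccc1` is fluoro in place of chloro on an aromatic carbon and it lies para to a large group.

For the measured compounds named here, two measured steps bear on this. The closer one is an at least 13-fold higher number from compound 1 to compound 3 (1.13 log units; beyond the scatter) and it came with chloro in place of methoxy at this same place, so a swap here can shift the read-out strongly. The other is a step that the two limits leave unreadable from compound 2 to compound 3 and it gives no size. With compound 3 only a limit, any readable step can run only towards lower numbers in this assay and thus stronger inhibition. Fluoro is not methoxy, so only a modest step of that kind is expected, and compound 4 may well stay at the limit. The step expected is an at least 1.4-fold lower number from compound 3 to compound 4 (0.15 log units; that floor lies within the scatter) by this estimate. For compound 4 the estimated value is 7000 nM with an expected range from 2000 nM to 20000 nM in this read-out.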

Compound 4, half-maximal inhibitory concentration: > 10000 nM
Compound 4 gave a limit, no number; the forecaster's own chance of this, stated with the estimate: 50%; at least 1.4-fold (0.15 log units) between middle value and limit.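

In this assay, fluoro in place of chloro on this aromatic carbon brings no number into view, so the 4-fluorophenyl of compound 4 is no better resolved than the 4-chlorophenyl of compound 3. Steps between two limits, here compound 3 to compound 4 and compound 2 to compound 3, cannot be read. What is new is that a second replacement of the methoxy of compound 1 gives a large step, an at least 13-fold higher number from compound 1 to compound 4 (1.13 log units; beyond the scatter), of the same printed size as the one with chloro, an at least 13-fold higher number from compound 1 to compound 3 (1.13 log units; beyond the scatter), so this large step at this place is not tied to chloro alone, and compound 4 adds one more compound at the ceiling of the read-out: the limit of > 10000 nM in this assay, at which 3 of the 4 values shown sit.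

On these data alone, how far beyond the limit compound 3 and compound 4 lie, and whether they differ at all, stays open. So does whether a different group at this place, such as an ethoxy, a hydroxy or an amine, would give a number in this assay as the methoxy of compound 1 does.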